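This account rests on a few compounds, and the source may have more. Where it says the series, first, only, none or still open, it means among the compounds named here.

Series notes. Compound 1 `Cc1cc(C#N)cc(C)c1Oc1cc(Cl)nc(NCCn2ccc(=O)[nH]c2=O)n1` and compound 2 `Cc1cc(/C=C/C#N)cc(C)c1Oc1cc(N)nc(NCCn2ccc(=O)[nH]c2=O)n1` have been run in an ADME assay on MT4 cells (Homo sapiens) for cytotoxicity, read by MTT assay, with a stated time of 5 days; on this read-out higher numbers stand for lower toxicity in this test and lower numbers for higher toxicity in this test. In this assay compound 1 gives 20600 nM. For compound 2 the this assay read-out is only a limit, > 298000 nM, so compound 2 sits at the limit of > 298000 nM in this assay, at which 1 of the 2 values shown sits, and no number is fixed for it. Compound 3 `Cc1cc(/C=C/C#N)cc(C)c1Oc1cc(Cl)nc(NCCn2ccc(=O)[nH]c2=O)n1` is not yet measured; it differs from compound 2 by chloro in place of amino on an aromatic carbon. Compound 1 carries the same chloro and gives 20600 nM in this assay, which points to a numbered result for compound 3. The expected step in this assay is an at least 9.9-fold lower number from compound 2 to compound 3 (0.99 log units; beyond the scatter). Compound 3 is estimated at 30000 nM, with a range of 8000 nM to 150000 nM.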

Compound 3, half-maximal cytotoxic concentration: > 284000 nM
Compound 3: no number, only a limit (the forecaster's own chance of this, stated with the estimate: 25%); at least 9.4-fold (0.97 log units) between middle value and limit.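

In this assay, with chloro held in place, 2-cyanoethenyl in place of cyano on an aromatic carbon gives an at least 13-fold higher number from compound 1 to compound 3 (1.13 log units; beyond the scatter). Compound 3 reads only as a limit, and so does compound 2 with amino at this carbon, so chloro here does not by itself give a numbered result when 2-cyanoethenyl is present. The step between these two limits cannot be read.

As far as these compounds go, how far chloro and amino differ at this carbon remains open. So does whether a methoxy or dimethylamino group there would give a numbered result.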